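This account rests on a few compounds, and the source may have more. Where it says the series, first, only, none or still open, it means among the compounds named here.

Measured so far:
compound 1 `O=C(/C=C/C(=O)N1C/C(=C\c2ccccc2)C(=O)/C(=C/c2ccccc2)C1)Nc1ccc([N+](=O)[O-])cc1`: 40000 nM
compound 2 `O=C(/C=C/C(=O)N1C/C(=C\c2ccc([N+](=O)[O-])cc2)C(=O)/C(=C/c2ccc([N+](=O)[O-])cc2)C1)Nc1ccc([N+](=O)[O-])cc1`: 1000 nM

In a functional assay on L1210 cells (Mus musculus) for cytotoxicity (on this read-out lower numbers stand for stronger inhibition and higher numbers for weaker inhibition), compound 1 gives the highest of the two numbers; the nearest is compound 2, whose number is lower by a margin beyond the scatter. Compound 3 `Cc1ccc(NC(=O)/C=C/C(=O)N2C/C(=C\c3ccccc3)C(=O)/C(=C/c3ccccc3)C2)cc1` differs from compound 1 by methyl in place of nitro on an aromatic carbon. Going by the values given here, no measured pair in this set shows a change of this kind, so the size of the step rests on expectation alone. The two values at hand come from a change on another part of the shared core and say nothing direct about the part where the new change sits. Compound 3 is expected to stay close to compound 1, with the step of a 1.5-fold higher number from compound 1 to compound 3 (0.18 log units; within the scatter) expected to be small and, if anything, toward a higher number. The estimate for compound 3 in this assay is 60000 nM, with a range from 15000 nM to 200000 nM.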

Compound 3, half-maximal inhibitory concentration: 5800 nM
The estimate for compound 3 lay 10-fold (1.01 log units) above the measured number; the whole stated range lies above it.
By their numbers in this assay, from the lowest: compound 2; then compound 3; then compound 1.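

In this assay, the aromatic carbon para to a large group, on the carbamoyl end of the shared core, responds to substitution: methyl in place of nitro gives a 6.9-fold lower number from compound 1 to compound 3 (0.84 log units; beyond the scatter). Going by these compounds alone, a nitro group at this position is therefore not required for activity in compound 3, and on this core the methyl-bearing compound gives the lower number, which the earlier compounds, with their shared 4-nitrophenyl group, could not show. No measurement at hand explains this step.

From the compounds shown here alone, with one replacement at this position, no trend across substituents can yet be drawn, and the effect of an amine, a carboxylic acid or a methoxy group on the same aromatic carbon remains open. Also open, going by these compounds, is whether 4-methylphenyl in place of 4-nitrophenyl gives a similar step alongside the further nitro groups of compound 2.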